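The source may hold more compounds than are shown below. What is called first, only, known or untested is meant among the compounds shown, and "the series" means these compounds.

Notes on the series. In a functional assay on A549 cells (Homo sapiens) for inhibition, read by sulforhodamine B assay, with a stated time of 72 h (on this read-out higher numbers stand for weaker inhibition and lower numbers for stronger inhibition), compound 1 `C#Cc1cccc(Nc2ncnc3cc(OCCCCn4ccnc4[N+](=O)[O-])c(OC)cc23)c1` gives 1080 nM. Compound 2 `C#Cc1cccc(Nc2ncnc3cc(OCCCCCn4ccnc4[N+](=O)[O-])c(OC)cc23)c1` carries (2-nitro-1H-imidazol-1-yl)methyl in place of 2-nitro-1H-imidazol-1-yl on a saturated chain carbon, four bonds along the chain from an oxygen on an aromatic ring and gives 180 nM, so that a 6.0-fold lower number from compound 1 to compound 2 (0.78 log units; beyond the scatter). Compound 3 `COc1cc2c(Nc3cccc(Br)c3)ncnc2cc1OCCCCCn1ccnc1[N+](=O)[O-]` gives 8420 nM, and a 47-fold higher number from compound 2 to compound 3 (1.67 log units; beyond the scatter). The difference between the core of compound 1 and the core of compound 3 is not broken down here. Compound 4 `COc1cc2c(Nc3cccc(Br)c3)ncnc2cc1OCCCCCCn1ccnc1[N+](=O)[O-]` has not yet been measured; against compound 3 it carries (2-nitro-1H-imidazol-1-yl)methyl in place of 2-nitro-1H-imidazol-1-yl on a saturated chain carbon, five bonds along the chain from an oxygen on an aromatic ring. This is the same kind of change as from compound 1 to compound 2, but the place differs: five bonds along the chain from an oxygen on an aromatic ring rather than four. Compound 4 is expected to give 2800 nM, with a range of 800 nM to 12000 nM. For compound 4 the estimated step is a 3.0-fold lower number from compound 3 to compound 4 (0.48 log units; beyond the scatter). A smaller step than before is expected because a 6.0-fold lower number from compound 1 to compound 2 (0.78 log units; beyond the scatter) rests on a single pair on a different core.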

Compound 4, half-maximal inhibitory concentration: 20200 nM
Beside the measured number, compound 4's estimate is 7.2-fold (0.86 log units) below it; the measured number lies above the stated range.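

In this assay, the change from 2-nitro-1H-imidazol-1-yl to (2-nitro-1H-imidazol-1-yl)methyl gives a 2.4-fold higher number from compound 3 to compound 4 (0.38 log units; beyond the scatter), so its direction does not carry over between these two cores: the same change on two cores in this assay, a 6.0-fold lower number (0.78 log units; beyond the scatter) from compound 1 to compound 2 and a 2.4-fold higher number (0.38 log units; beyond the scatter) from compound 3 to compound 4, 14-fold (1.16 log units) apart, beyond the scatter of two such steps

A step read on one core is therefore no guide to the other in this pair of pairs. The two pairs also differ in place, four bonds along the chain from the oxygen in one and five in the other, so the data do not show whether core or chain length sets the difference.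

Open, going by these compounds, is whether a longer chain on the core of compound 1 would also raise the number. Also open, on these data alone, is how a plain imidazole would compare with the 2-nitro-1H-imidazol-1-yl group on either core.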